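Ring ester to acid on the peracetylated pentadecyl series

The source may report more compounds than this note shows. Statements on the series, on what has been measured and on what is new or still open speak of the compounds shown alone.

Compound 1 `C/C=C1/[C@H](O[C@@H]2O[C@H](CO)[C@@H](O)[C@H](O)[C@H]2O)OC=C(C(=O)OC)[C@H]1CC(=O)O` and compound 3 `C/C=C1/[C@H](O[C@@H]2O[C@H](CO)[C@@H](O)[C@H](O)[C@H]2O)OC=C(C(=O)OC)[C@H]1CC(=O)OC` share the free-sugar core; compound 2 `C/C=C1/[C@H](O[C@@H]2O[C@H](COC(C)=O)[C@@H](OC(C)=O)[C@H](OC(C)=O)[C@H]2OC(C)=O)OC=C(C(=O)OC)[C@H]1CC(=O)OCCCCCCCCCCCCCCC` carries the peracetylated sugar and the pentadecyl ester. How the core of compound 2 differs from that of compound 3 is not broken down here. In a functional assay on SK-BR-3 cells (Homo sapiens) for antiproliferative activity, read by MTT assay, with a stated time of 72 h (on this read-out higher numbers stand for weaker inhibition and lower numbers for stronger inhibition), compound 3 gives a limit, > 15000 nM. In this assay compound 1 also gives a limit, > 15000 nM. Compound 2 gives 3810 nM in this assay. The step that the two limits leave unreadable from compound 3 to compound 1 cannot be read because the limit of > 15000 nM in this assay, at which 2 of the 3 values shown sit, covers both ends: hydrogen in place of methyl on an oxygen next to a carbonyl group. Compound 4 `C/C=C1/[C@H](O[C@@H]2O[C@H](COC(C)=O)[C@@H](OC(C)=O)[C@H](OC(C)=O)[C@H]2OC(C)=O)OC=C(C(=O)O)[C@H]1CC(=O)OCCCCCCCCCCCCCCC` applies the same change, (hydrogen in place of methyl on an oxygen next to a carbonyl group), to compound 2, here read one bond further out as methoxycarbonyl to carboxy only. With the measured step unreadable, compound 4 is expected to sit near compound 2 or weaker, estimated at 8000 nM, that is a 2.1-fold higher number from compound 2 to compound 4 (0.32 log units; beyond the scatter).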

Compound 4, half-maximal inhibitory concentration: > 20000 nM
Compound 4: only a limit was reported; the forecaster's own chance of this, stated with the estimate: 40%; middle value at least 2.5-fold (0.39 log units) away from the limit.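

In this assay, hydrogen in place of methyl on an oxygen next to a carbonyl group gives an at least 5.2-fold higher number from compound 2 to compound 4 (0.72 log units; beyond the scatter), a clear loss on the peracetylated pentadecyl core. From the compounds shown here alone, compound 4 gives > 20000 nM, which is a limit and not a number, and the full size of this step remains unknown. The same change on the free-sugar core cannot be read, and nothing here shows whether the step carries over between the two cores in size: the limit of > 15000 nM in this assay, at which 2 of the 4 values shown sit.

Going by these compounds, whether an ethyl ester or a primary amide in place of methoxycarbonyl would keep the activity of compound 2 remains open. So does the effect of a decyl chain in place of pentadecyl.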